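Bromo to methoxymethyl on the fused core of compound 1

This account rests on a few compounds, and the source may have more. Where it says the series, first, only, none or still open, it means among the compounds named here.

Measured so far:
compound 1 `Oc1nnc(Br)c2c(Br)nc(Br)n12`: 27000 nM
compound 2 `CCCc1cnc(Nc2cc[nH]n2)n2c(CCC)nc(C)c12`: > 48000 nM
compound 3 `CCCc1ncc2cnnc(O)n12`: > 48000 nM

Within the data shown here, in a functional assay for inhibition, with Homo sapiens as the target (on this read-out lower numbers stand for stronger inhibition and higher numbers for weaker inhibition), compound 1 gives 27000 nM and is the only compound of the three with a number. For compound 2 the read-out in this assay is a limit of the assay, > 48000 nM, and not a number. For compound 3 the read-out in this assay is likewise a limit, > 48000 nM. The series therefore sits at or near (the limit of > 48000 nM in this assay, at which 2 of the 3 values shown sit), and compound 1 stands as the one weak but measurable inhibitor.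

Compound 4 `COCc1nc(Br)c2c(Br)nnc(O)n12` differs from compound 1 by methoxymethyl in place of bromo on an aromatic carbon. Among the measured compounds shown here, no step between two measured compounds is available to size this kind of change. The expectation for the step from compound 1 to compound 4 in this assay is no shift beyond the usual scatter, with the possibility that the read-out falls back to a limit; the estimated step is a 1.3-fold higher number from compound 1 to compound 4 (0.11 log units; within the scatter). Compound 4 is estimated at 35000 nM in this assay, with a range from 12000 nM to 100000 nM.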

Compound 4, half-maximal inhibitory concentration: > 48000 nM
Compound 4: a limit, no number (the forecaster's own chance of this, stated with the estimate: 40%); at least 1.3-fold (0.13 log units) between middle value and limit.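

In this assay, compound 4 returns a limit of the assay and not a number, > 48000 nM. This gives the first read at this position, on an aromatic carbon between two ring nitrogen atoms: methoxymethyl in place of bromo gives an at least 1.7-fold higher number from compound 1 to compound 4 (0.24 log units; that floor lies within the scatter), so the change does not keep a measurable number, yet no loss beyond the scatter is established. Compound 1 therefore remains the only compound in the series with a number, and the series now sits more firmly at its limit: the limit of > 48000 nM in this assay, at which 3 of the 4 values shown sit.

As far as these compounds go, the true size of the step remains open, as the limit for compound 4 gives only a floor. Also open, from the compounds shown here alone, is whether chloro or an amine on this aromatic carbon would keep a measurable number while the two other bromo groups stay in place.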